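Methyl for Fluoro on the Benzyl Ring

A few compounds are considered here, and "the series" means these few. Any claim that something is new, unique, unknown or untested is made for them only; others in the source may bear on it.

For the measured compounds named here, compound 2 `O=C(Nc1cccnc1)c1ccccc1OCc1ccccc1F` gives the lowest of the two numbers measured so far in an assay on lysate for inhibition of phosphatidylcholine:ceramide cholinephosphotransferase 2 (Homo sapiens), read by HPLC, with stated times of 30 min and 2 h (a lower number here means a stronger inhibitor, a higher number a weaker inhibitor), at 3500 nM. Compound 1 `O=C(NCc1ccco1)c1ccccc1OCc1ccccc1`, a differently built compound, gives 49000 nM in this assay, a higher number beyond the scatter. Compound 3 `Cc1ccccc1COc1ccccc1C(=O)Nc1cccnc1` differs from compound 2 only in methyl in place of fluoro on an aromatic carbon. Going by the values given here, no measured pair shows this change, so the expected step is small, read as a 1.2-fold lower number from compound 2 to compound 3 (0.07 log units; within the scatter), most likely within the scatter. Compound 3 is therefore estimated at 3000 nM, within a range from 1000 nM to 10000 nM.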

Compound 3, half-maximal inhibitory concentration: 1500 nM
Compound 3: middle estimate off by 2.0-fold (0.30 log units), on the high side, and the stated range covers the measured number.
By their numbers in this assay, from the lowest: compound 3; then compound 2; then compound 1.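

Going from 2-fluorobenzyl to 2-methylbenzyl is the first single-place change available here, and in this assay it gives a 2.3-fold lower number from compound 2 to compound 3 (0.37 log units; beyond the scatter). This shows that the aromatic carbon ortho to a large group is sensitive to what it carries, and that methyl is the better of these two groups there by a modest margin. No measurement at hand accounts for this step.

The compounds shown leave open how an amine, a methoxy group or chloro would read on this carbon. They also leave open whether the same change carries over to the core of compound 1.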